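A Methyl Added to the Benzoyl Ring

The compounds below may be only part of what the source reports. "The series", "measured", "known", "first", "only" and "open" are said of these compounds alone.

Compound 1 `COc1ccc(-c2cc(/C=C/C(=O)c3cc(OC)c(OC)c(OC)c3)nc3cc(-c4ccccc4)nn23)cc1OC` gives 35000 nM in an ADME assay on HEK293 cells (Homo sapiens) for antiproliferative activity, read by MTT assay, with a stated time of 24 h; on this read-out higher numbers stand for weaker inhibition and lower numbers for stronger inhibition. Compound 2 `COc1ccc(C(=O)/C=C/c2cc(-c3ccc(OC)c(OC)c3)n3nc(-c4ccccc4)cc3n2)cc1OC` gives 32500 nM, and compound 3 `COc1ccc(-c2cc(/C=C/C(=O)c3ccccc3)nc3cc(-c4ccccc4)nn23)cc1OC` gives 51200 nM. Compound 3 holds the highest of the three numbers, yet both steps toward it stayed within the scatter: a 1.5-fold higher number from compound 1 to compound 3 (0.17 log units; within the scatter) and a 1.6-fold higher number from compound 2 to compound 3 (0.20 log units; within the scatter). Compound 4 `COc1ccc(-c2cc(/C=C/C(=O)c3ccc(C)cc3)nc3cc(-c4ccccc4)nn23)cc1OC` differs from compound 3 by one change: methyl in place of hydrogen on an aromatic carbon. The two measured steps that altered the same benzoyl ring, trading 3,4,5-trimethoxyphenyl or 3,4-dimethoxyphenyl for plain phenyl, moved the number little, so a single methyl on that ring is expected to do no more, and the step of a 1.0-fold lower number from compound 3 to compound 4 (0.01 log units; within the scatter) is estimated to stay within the scatter. Compound 4 is therefore expected to give about 50000 nM, with a likely range from 25000 nM to 100000 nM.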

Compound 4, half-maximal inhibitory concentration: 62600 nM
Estimate against measurement, compound 4: 1.3-fold (0.10 log units) below; the range from low to high includes it.
By their numbers in this assay, from the lowest: compounds 2, 1, 3 and 4 (each within the scatter of the next).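

On the six-membered aromatic ring of the benzoyl group, a methyl para to a large group leaves the number within the scatter (a 1.2-fold higher number from compound 3 to compound 4 (0.09 log units; within the scatter)). In this assay, 4-methylphenyl also cannot be told apart from either methoxy-bearing ring (a 1.9-fold higher number from compound 2 to compound 4 (0.28 log units; within the scatter); a 1.8-fold higher number from compound 1 to compound 4 (0.25 log units; within the scatter)), so none of these four rings stands out. No measurement offers an explanation for this result.

From the compounds shown here alone, whether an amine or a carboxylic acid at this same place would move the number beyond the scatter remains open.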